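A few compounds are considered here, and "the series" means these few. Any claim that something is new, unique, unknown or untested is made for them only; others in the source may bear on it.

Of the compounds shown here, three sharing one core have been tested in a functional assay on U2OS cells (Homo sapiens) for cytotoxicity, read by MTT assay, with a stated time of 48 h; on this read-out lower numbers stand for stronger inhibition and higher numbers for weaker inhibition. Compound 1 `Fc1ccc(Nc2nc(-c3cccc(F)c3)nc3ccc(F)cc23)cc1` gives only a limit there, > 50000 nM. Compound 2 `Fc1cccc(-c2nc(Nc3ccccc3F)c3cc(F)ccc3n2)c1` likewise gives only a limit in this assay, > 50000 nM. Compound 3 `Fc1cccc(-c2nc(Nc3ccc(Br)cc3)c3cc(F)ccc3n2)c1` also gives only a limit in this assay, > 50000 nM. Compound 3 thus stands where every measured compound stands, at the limit of > 50000 nM in this assay, at which 3 of the 3 values shown sit. The steps among the three cannot be sized: a step that the two limits leave unreadable from compound 1 to compound 2, a step that the two limits leave unreadable from compound 1 to compound 3 and a step that the two limits leave unreadable from compound 2 to compound 3. Compound 4 `Oc1cccc(Nc2nc(-c3cccc(F)c3)nc3ccc(F)cc23)c1` has not yet been measured. It differs from compound 3 in one place: 3-hydroxyphenyl in place of 4-bromophenyl on a nitrogen on an aromatic ring. Within the data shown here, none of the measured steps carries a readable size, so they give no ground for expecting a step beyond the scatter in either direction; they show only that every change tried so far left the compound at the limit. For compound 4 in this assay the expected value is 50000 nM, with a range from 10000 nM to 150000 nM. That estimate means an expected step of a number no higher from compound 3 to compound 4 (the limit leaves the size open), most likely again a limit rather than a number.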

Compound 4, half-maximal inhibitory concentration: 33300 nM
For compound 4 the middle estimate is 1.5-fold (0.18 log units) above the measured one, and the stated range covers the measured number.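

With 3-hydroxyphenyl on the nitrogen, the series gives its first number rather than a limit: in this assay compound 4 gives 33300 nM. On these data alone, the change reads as an at least 1.5-fold lower number from compound 3 to compound 4 (0.17 log units; that floor lies within the scatter), as an at least 1.5-fold lower number from compound 2 to compound 4 (0.17 log units; that floor lies within the scatter) and as an at least 1.5-fold lower number from compound 1 to compound 4 (0.17 log units; that floor lies within the scatter), so each step has only a floor, its full size stays open, and no gain beyond the scatter can be claimed. The steps among compounds 1, 2 and 3 cannot be read, and those three compounds remain at a limit: the limit of > 50000 nM in this assay, at which 3 of the 4 values shown sit.

Compound 4 differs from compound 3 in both the group and its place on the ring, so the two effects cannot be separated. As far as these compounds go, whether the hydroxy group itself matters also stays open, as a methoxy group or an amine in its place would be needed to test it.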